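The source may hold more compounds than are shown below. What is called first, only, known or untested is meant among the compounds shown, and "the series" means these compounds.

Measured compounds:
compound 1 `COCc1cc(OC)c(-c2cccc3c(N(CC4CC4)CC4OCCCO4)c(SC)nn23)c(OC)c1`: 113 nM
compound 2 `COCc1cc(OC)c(-c2cccc3c(N(CC4CCOCC4)CC4(O)CC4)c(SC)nn23)c(OC)c1`: 98 nM
compound 3 `CCc1nn2c(-c3c(C)cc(C)cc3OC)cccc2c1N(CC1CC1)CC1CCOC1`: 38 nM

In an assay on HEK293 cells for displacement of a labelled ligand from corticotropin-releasing factor receptor 1 (Homo sapiens), read by scintillation counting, with a stated time of 2 h (a lower number here means a stronger inhibitor, a higher number a weaker inhibitor), compound 3 gives the lowest of the three numbers; compound 2 sits a clear gap above it, and compound 1 sits furthest away, both gaps beyond the scatter. Compound 4 `CCc1nn2c(-c3c(C)cc(C)cc3OC)cccc2c1N(CCCF)CC1CC1` is not yet measured and differs from compound 3 in one place: 2-fluoroethyl in place of oxolan-3-yl on a saturated chain carbon bound to a nitrogen on an aromatic ring. Going by the values given here, no single-change step between measured compounds is available, so the size of this change is open. The step from compound 3 to compound 4 is expected to be small, a 1.6-fold higher number from compound 3 to compound 4 (0.20 log units; within the scatter), towards a somewhat higher number, though it may well stay within the scatter. Compound 4 is therefore estimated at 60 nM in this assay, in the range 20 nM to 180 nM.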

Compound 4, half-maximal inhibitory concentration: 20 nM
Compound 4: the middle estimate sits 3.0-fold (0.48 log units) above what was measured, and the stated range covers the measured number.
By their numbers in this assay, from the lowest: compounds 4 and 3 (each within the scatter of the next); then compounds 2 and 1 (each within the scatter of the next).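

At this place, on a saturated chain carbon bound to a nitrogen on an aromatic ring, this assay gives the first single-change step, a 1.9-fold lower number from compound 3 to compound 4 (0.28 log units; within the scatter), which is within the scatter. Exchanging oxolan-3-yl, with its ring and hydrogen-bond acceptor, for the open-chain 2-fluoroethyl therefore leaves the number indistinguishable from that of compound 3. Nothing available explains this result. The compounds shown leave open whether an amine or a carboxylic acid at this place would hold the number. They also leave open how a longer chain would read.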